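A few compounds are considered here, and "the series" means these few. Any claim that something is new, unique, unknown or untested is made for them only; others in the source may bear on it.

Among the compounds with values here, compound 3 `O=C(Nc1cccc(-n2cc(-c3ccncc3)c(-c3cc(O)cc(Cl)c3)n2)c1)Nc1ccc(Cl)c(Cl)c1` gives -70.3% in a functional assay on RXF 393 cells (Homo sapiens) for inhibition, read by sulforhodamine B assay, with a stated time of 48 h, tested at 10 uM (on this read-out lower numbers stand for a stronger effect and higher numbers for a weaker effect at the one concentration tested), the lowest of the three numbers so far. Compound 1 `COc1cc(Cl)cc(-c2nn(-c3cccc(NC(=O)Nc4cccc(C(F)(F)F)c4)c3)cc2-c2ccncc2)c1` gives 11.8% and compound 2 `COc1cc(Cl)cc(-c2nn(-c3cccc(NC(=O)c4cccc(C(F)(F)F)c4)c3)cc2-c2ccncc2)c1` gives 40.5%; both lie beyond the scatter above compound 3. Compound 4 `COc1cc(Cl)cc(-c2nn(-c3cccc(NC(=O)Nc4ccc(Cl)c(Cl)c4)c3)cc2-c2ccncc2)c1` differs from compound 3 by methyl in place of hydrogen on an oxygen on an aromatic ring. Within the data shown here, the single measured step, a number 28.7 percentage points higher from compound 1 to compound 2 (beyond the scatter), concerns a different part of the shared core and does not bear on this change; no measured pair shows hydroxy against methoxy with everything else held constant. Compound 1 and compound 2 carry the methoxy group and compound 3 the hydroxy, but they differ elsewhere too, so only a weak hint remains. The expected step is a number 40.3 percentage points higher from compound 3 to compound 4 (beyond the scatter), with wide uncertainty. Compound 4 is estimated at -30%, within a range from -80% to 20%.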

Compound 4, a percentage reported as activity, at one concentration (the size of the read-out at that concentration, not a potency): 4.46%
The estimate for compound 4 lay 34.5 percentage points below the measured number; the measured number falls inside the stated range.
By their numbers in this assay, from the lowest: compound 3; then compounds 4 and 1 (each within the scatter of the next); then compound 2.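

In this assay, hydroxy to methoxy now has a matched pair: a number 74.8 percentage points higher from compound 3 to compound 4 (beyond the scatter), so the free hydroxy on the aromatic ring carries a large step that compounds 1 and 2 could not show. With methoxy held, a number 36 percentage points lower from compound 2 to compound 4 (beyond the scatter) for (3,4-dichlorophenyl)amino in place of 3-(trifluoromethyl)phenyl on the carbonyl carbon. The aryl swap on the amide-type nitrogen stays within the scatter, a number 7.3 percentage points lower from compound 1 to compound 4 (within the scatter). Nothing at hand explains the hydroxy step. From the compounds shown here alone, whether an amine or an ethoxy group in that place reads like compound 3 stays open, as does whether the hydroxy step holds with 3-(trifluoromethyl)phenyl on the amide-type nitrogen.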